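The source may hold more compounds than are shown below. What is called first, only, known or untested is meant among the compounds shown, and "the series" means these compounds.

In an ADME assay on cells (spleen, Mus musculus, strain C57BL/6) for inhibition, read by flow cytometry and propidium iodide staining, with a stated time of 24 h, at 37 degrees C (on this read-out higher numbers stand for an effect only at larger amounts of compound and lower numbers for an effect already at smaller amounts), compound 1 (`O=C(Cn1cc(CCCCO)nn1)NCc1ccccc1`) gives 1700 uM as a measured number. Compound 2 (`CC(C)(C)OC(=O)NCc1cn(CC(=O)NCc2ccccc2)nn1`) stands at > 2000 uM as a limit of the assay and not a number. That limit is all that is known of its position, and the limit of > 2000 uM in this assay, at which 1 of the 2 values shown sits, in this small series.

Compound 3 (`NCc1cn(CC(=O)NCc2ccccc2)nn1`) differs from compound 2 by one change, hydrogen in place of tert-butoxycarbonyl on an amine nitrogen, so that (tert-butoxycarbonyl)amino becomes amino. For the measured compounds named here, the only measured step involving this group is an at least 1.1-fold higher number from compound 1 to compound 2 (0.07 log units; that floor lies within the scatter) on exchange of 3-hydroxypropyl for (tert-butoxycarbonyl)amino. That step does not leave the scatter, and it gives no measured size for removing the group.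

Going by the values given here, an expected value for compound 3 therefore leans on compound 1 at 1700 uM as the one number, and no large move is expected. The estimated change is an at least 1.3-fold lower number from compound 2 to compound 3 (0.12 log units; that floor lies within the scatter) in this assay on this basis. Compound 3 is estimated at 1500 uM with an expected range from 600 uM to 2500 uM for a single measurement.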

Compound 3, concentration for half-maximal effect: > 2000 uM
Compound 3 was reported as a limit; the forecaster's own chance of this, stated with the estimate: 45%; at least 1.3-fold (0.12 log units) between middle value and limit.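

In this assay, for the compounds shown here, replacing 3-hydroxypropyl with amino gives an at least 1.1-fold higher number from compound 1 to compound 3 (0.07 log units; that floor lies within the scatter), so the free amino group, like (tert-butoxycarbonyl)amino before it, shows no step past the scatter on this saturated chain carbon bound to an aromatic carbon. Compound 2 and compound 3 are both reported as limits of the assay, so the step between them cannot be read and removing tert-butoxycarbonyl from the amine nitrogen has no measured size. What the series adds is that the amine, with or without tert-butoxycarbonyl, ends at the same limit, and that limit now holds most of the data: the limit of > 2000 uM in this assay, at which 2 of the 3 values shown sit.

Only compound 1 gives a number, 1700 uM. From the compounds shown here alone, how far compound 2 and compound 3 lie past their limits stays open. Also open, going by these compounds, is whether a carboxylic acid or a longer chain ending in an amine at this saturated chain carbon would bring a measured number in this assay, and whether any such number would differ from that of compound 1 by more than the scatter.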